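The source may hold more compounds than are shown below. What is called first, only, known or untested is meant among the compounds shown, and "the series" means these compounds.

Measured in an ADME assay on MT4 cells (Homo sapiens) for activation, read by MTT assay (a higher number here means that more compound is tolerated, a lower number that less compound is tolerated), all values being limits:
- Compound 1 `CC(C)Sc1nc(Cc2c(F)cccc2Cl)cc(=O)[nH]1`: > 80000 nM
- Compound 2 `CCCSc1nc(Cc2c(F)cccc2Cl)cc(=O)[nH]1`: > 80000 nM
- Compound 3 `Cc1c(Cc2c(F)cccc2Cl)nc(SC(C)C)[nH]c1=O`: > 76000 nM

Compound 3 stands at a limit, > 76000 nM. The other two values are limits as well, so no number is available for any of the three compounds.

The next structure is compound 4 `CCCSc1nc(Cc2c(F)cccc2Cl)c(C)c(=O)[nH]1`, and the change is propyl in place of isopropyl on a sulfur. The same change has been measured once, as a step that the two limits leave unreadable from compound 1 to compound 2. The other measured change, methyl in place of hydrogen on an aromatic carbon, appears as a step that the two limits leave unreadable from compound 1 to compound 3. Neither gives a size to carry over, but neither shows any sign of a fall in the tolerated concentration. No step beyond the usual scatter is therefore expected in this assay, and a further limit is the likeliest result. The expected change is a step that the limit leaves unreadable from compound 3 to compound 4. For compound 4 the estimated value is 78000 nM, with an expected range from 35000 nM to 160000 nM.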

Compound 4, half-maximal cytotoxic concentration: > 76000 nM
Compound 4 was reported as a limit; the forecaster's own chance of this, stated with the estimate: 80%; the middle value does not contradict the limit.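

Compound 4 is reported only as a limit, as are compound 2 and compound 3, so neither the step from compound 3 to compound 4 nor the step from compound 2 to compound 4 can be read. The compounds shown leave open at what concentration any of them becomes cytotoxic in this assay.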